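Trimming a Benzofuran to a Furan on a Shared Core

A few compounds are considered here, and "the series" means these few. Any claim that something is new, unique, unknown or untested is made for them only; others in the source may bear on it.

Of the compounds shown here, three built on one shared core have been tested in an assay on isolated protein for agonist activity at Bile acid receptor (Homo sapiens), read by AlphaScreen, with a stated time of 30 min; a lower number here means that less compound is needed, a higher number that more compound is needed for the effect. Compound 1 `COc1ccccc1-n1nc(C)c2c1NC(=O)[C@H](C)S[C@@H]2c1ccc(Oc2ccccc2)cc1` gives 3300 nM, compound 2 `Cc1ccccc1-n1nc(C)c2c1NC(=O)[C@H](C)S[C@@H]2c1ccc(-c2cc3ccccc3o2)cc1` gives 1500 nM, and compound 3 `Cc1nn(-c2ccccc2C(F)(F)F)c2c1C(c1ccc(Oc3ccccc3)cc1)SC(C)C(=O)N2` gives 2000 nM. Compound 2 carries the smallest of the three numbers; compound 3 lies within the usual scatter of it, while compound 1 lies beyond that scatter. Compound 4 `Cc1ccccc1-n1nc(C)c2c1NC(=O)[C@H](C)S[C@@H]2c1ccc(-c2ccco2)cc1` differs from compound 2 in a single place: furan-2-yl in place of 1-benzofuran-2-yl on an aromatic carbon. For the measured compounds named here, no measured pair shows this change, so the expectation rests on the change alone. A modest move toward a higher number is expected, with an estimated step of a 2.3-fold higher number from compound 2 to compound 4 (0.37 log units; beyond the scatter). Compound 4 is therefore expected to give roughly 3500 nM, within a range from 1200 nM to 10000 nM.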

Compound 4, half-maximal effective concentration: 3600 nM
The estimate for compound 4 lay 1.0-fold (0.01 log units) below the measured number, within the range that was stated.
By their numbers in this assay, from the lowest: compounds 2, 3, 1 and 4 (each within the scatter of the next, the first and the last beyond it).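

For the compounds shown here, compound 2 and compound 4 are the first pair here to differ in one place only, so this position can now be read directly: in this assay, furan-2-yl in place of 1-benzofuran-2-yl gives a 2.4-fold higher number from compound 2 to compound 4 (0.38 log units; beyond the scatter). In this single pair, losing the six-membered aromatic ring of carbon only goes with a higher number, so that ring matters at this position. Nothing available explains the step.

Going by these compounds, it remains open how an amine or a carboxylic acid would fare at this position, and whether the same step would appear with other groups elsewhere on the shared core.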